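This account rests on a few compounds, and the source may have more. Where it says the series, first, only, none or still open, it means among the compounds named here.

Compounds measured so far:
- Compound 1 `O=C1c2ccc(OCc3cccc(-c4ccccc4)c3)cc2CN1C1CCCC1`: 95%
- Compound 2 `CN(C)C(=O)c1cc(-c2cccc(COc3ccc4c(=O)n(C5CCCC5)sc4c3)c2)ccc1Cl`: 100%
- Compound 3 `O=C(O)c1cc(-c2cccc(COc3ccc4c(=O)n(C5CCC5)sc4c3)c2)ccc1Cl`: 91%

These numbers come from an ADME assay on a cell-free system (plasma, Rattus norvegicus) for metabolic stability, read by LC-MS, with a stated time of 1 h, at 37 degrees C, tested at 100 uM; a lower number here means that less of the compound is left, a higher number that more of the compound is left. Compound 1 gives 95%, which lies within the usual scatter of the values for both other compounds. The three compounds therefore cannot be ranked on this evidence, and nearly all of each compound is still present at the end of the test.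

The next compound is compound 4 `O=C(O)c1ccc(Cl)c(-c2cccc(COc3ccc4c(c3)CN(C3CCCC3)C4=O)c2)c1`, which has not yet been measured. It keeps the core of compound 1 and puts 5-carboxy-2-chlorophenyl in place of phenyl on an aromatic carbon.

Going by the values given here, no two measured compounds differ in just one place, so the size of this change cannot be read directly from a matched pair. The closest guide is compound 3, which also carries a carboxy group and gives 91% in this assay. Compound 2, which has no such acid group, gives 100%. On that basis, no step beyond the scatter is expected. The estimated change is a number 1 percentage points lower from compound 1 to compound 4 (within the scatter). For compound 4, the expected value is 94%, with an estimated range from 85% to 102%.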

Compound 4, percent of the compound remaining: 100%
For compound 4 the middle estimate is 6 percentage points below the measured one, and the stated range covers the measured number.
By their numbers in this assay, from the lowest: compounds 3, 1, 2 and 4 (each within the scatter of the next).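

Going by these compounds alone, the pair of compound 1 and compound 4 is the first in this set to differ in one place, and in this assay it gives a number 5 percentage points higher from compound 1 to compound 4 (within the scatter). On the core of compound 1, then, phenyl on this aromatic carbon, meta to a large group, can give way to the larger 5-carboxy-2-chlorophenyl with no step beyond the usual scatter, even though the new group brings a carboxy group and a chlorine together. Nothing measured here explains why the two compounds read alike.

The carboxy group and the chlorine enter together, so this pair cannot show what either does alone, and it speaks only to this one read-out on this one core. It also leaves open whether a different group on this aromatic carbon, such as an amine, a nitrile or a longer alkyl chain in place of the substituted phenyl, would give a reading in this assay as close to that of compound 1.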